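Benzyl in place of 2-methylphenyl on the aromatic nitrogen

The compounds below may be only part of what the source reports. "The series", "measured", "known", "first", "only" and "open" are said of these compounds alone.

Compound 3 `Cc1ccccc1-n1cc(CNC(=O)c2cccc3c2cnn3C(C)C)nn1` carries a 2-methylphenyl group on an aromatic nitrogen of the shared core. In a functional assay on MCF7 cells (Homo sapiens) for inhibition, read by MTT assay, with a stated time of 72 h (on this read-out higher numbers stand for weaker inhibition and lower numbers for stronger inhibition), compound 3 gives > 40000 nM, which is a limit of the assay and not a number. Compound 1 `CC(C)n1ncc2c(C(=O)NCc3cn(-c4ccc([N+](=O)[O-])cc4)nn3)cccc21` likewise sits at a limit, giving > 40000 nM in this assay. Compound 2 `Cc1ccc(-n2cc(CNC(=O)c3cccc4c3cnn4C(C)C)nn2)cc1` also sits at a limit, with > 40000 nM. Because (the limit of > 40000 nM in this assay, at which 3 of the 3 values shown sit), the steps a step that the two limits leave unreadable from compound 1 to compound 2, a step that the two limits leave unreadable from compound 1 to compound 3 and a step that the two limits leave unreadable from compound 2 to compound 3 cannot be sized. Compound 4 `CC(C)n1ncc2c(C(=O)NCc3cn(Cc4ccccc4)nn3)cccc21` differs from compound 3 by benzyl in place of 2-methylphenyl on an aromatic nitrogen. Within the data shown here, no measured step bears directly on this change. With all three comparators at the limit, compound 4 is expected to remain at the limit as well, an expected step that the limit leaves unreadable from compound 3 to compound 4. The estimate for compound 4 is 50000 nM, with a range from 20000 nM to 150000 nM.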

Compound 4, half-maximal inhibitory concentration: 9170 nM
Estimate against measurement, compound 4: 5.5-fold (0.74 log units) above, outside the stated range (below it).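

Of the groups shown on this aromatic nitrogen, only benzyl gives a value in this assay that is a number and not a limit, with an at least 4.3-fold lower number from compound 3 to compound 4 (0.63 log units; beyond the scatter) and an at least 4.3-fold lower number from compound 2 to compound 4 (0.63 log units; beyond the scatter) and an at least 4.3-fold lower number from compound 1 to compound 4 (0.63 log units; beyond the scatter). Each of these steps gives only a minimum size, because the other end of each step is a limit: the limit of > 40000 nM in this assay, at which 3 of the 4 values shown sit. The compounds shown leave open whether a longer chain such as phenethyl on this nitrogen would lower the number further. They also leave open whether an amine or a carboxylic acid on the benzyl ring would keep this activity.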